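Pyrazoline series: propanoyl in place of nitrophenyl

The compounds below may be only part of what the source reports. "The series", "measured", "known", "first", "only" and "open" are said of these compounds alone.

Measured so far:
compound 1, `CCC(=O)N1N=C(c2ccc(C)cc2)CC1c1cn(-c2ccccc2)nc1-c1ccc(Cl)c(Cl)c1`: 29.8%
compound 2, `O=[N+]([O-])c1ccc(N2N=C(c3ccc(Cl)cc3)CC2c2cn(-c3ccccc3)nc2-c2ccc(Cl)c(Cl)c2)cc1`: 48.9%

In a functional assay on the whole organism (strain Wistar) for inhibition, with Rattus norvegicus as the target, read by paw edema, with a stated time of 30 min, at a dose of 50 mg/kg by the oral route (on this read-out higher numbers stand for more inhibition at the one dose given (going by the name of the read-out) and lower numbers for less inhibition), compound 2 gives 48.9% and stands highest of the two numbers; compound 1 gives 29.8%, a figure lower by more than the usual scatter. Within the data shown here, no step between measured compounds that differ in one place is available, so the two values are taken only as they stand.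

Compound 3, `CCC(=O)N1N=C(c2ccc(Cl)cc2)CC1c1cn(-c2ccccc2)nc1-c1ccc(Cl)c(Cl)c1`, has not been measured in this assay. The change from compound 2 is propanoyl in place of 4-nitrophenyl on an amine nitrogen in a ring. Compound 3 carries the same propanoyl group as compound 1 together with the 4-chlorophenyl group of compound 2. Compound 3 is expected to sit between the two measured values, with a downward step a number 12.9 percentage points lower from compound 2 to compound 3 (beyond the scatter) expected beyond the scatter, because compound 1 with its propanoyl gives 29.8%. The estimate for compound 3 is 36%, within 22% to 50%.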

Compound 3, a percentage reported as inhibition, in the whole organism at one dose (the size of the read-out at that dose, not a potency): 47.9%
Compound 3: middle estimate off by 11.9 percentage points, on the low side; low and high end bracket the measured number.
By their numbers in this assay, from the lowest: compound 1; then compounds 3 and 2 (each within the scatter of the next).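

In this assay, propanoyl in place of 4-nitrophenyl on an amine nitrogen in a ring reads as a number 1 percentage points lower from compound 2 to compound 3 (within the scatter), so at this position a small open acyl group and a large aromatic group cannot be told apart at the one dose given. With propanoyl held fixed, chloro in place of methyl on an aromatic carbon reads as a number 18.1 percentage points higher from compound 1 to compound 3 (beyond the scatter), so propanoyl alone does not set the low figure of compound 1, and the aromatic substituent matters in this pair. No measurement available here gives a reason for either step.

Open, from the compounds shown here alone, is whether the methyl-to-chloro step holds with 4-nitrophenyl on the ring nitrogen. Also open, going by these compounds, is how an acetyl group, a longer acyl chain or a carboxylic acid would read at this position.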